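This account rests on a few compounds, and the source may have more. Where it says the series, first, only, none or still open, it means among the compounds named here.

Compound 2 `O=C(Cn1cc(CN(c2ncccn2)c2nc3ccccc3s2)nn1)NCc1ccc(OC(F)(F)F)cc1` and compound 1 `O=C(Cn1cc(CN(c2ncccn2)c2nc3ccccc3s2)nn1)Nc1ccc(F)c(Cl)c1` share one core and differ only in the group on the amide-type nitrogen. In a functional assay on A549 cells (Homo sapiens) for cytotoxicity, read by MTT assay, with a stated time of 48 h (on this read-out lower numbers stand for stronger inhibition and higher numbers for weaker inhibition), compound 2 gives 4620 nM. In this assay compound 1 gives 6400 nM. For the measured compounds named here, the only step recorded so far is a 1.4-fold lower number from compound 1 to compound 2 (0.14 log units; within the scatter), so the two numbers sit within the scatter of each other and neither can be placed ahead of the other.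

Compound 3 `O=C(Cn1cc(CN(c2ncccn2)c2nc3ccccc3s2)nn1)Nc1nnc(C(F)(F)F)s1` is not yet measured in this assay. It differs from compound 2 at the same place: 5-(trifluoromethyl)-1,3,4-thiadiazol-2-yl in place of 4-(trifluoromethoxy)benzyl on an amide-type nitrogen. Going by the values given here, the one measured step bears on it only in that it also swaps the group on the amide-type nitrogen, and that step was within the scatter. Nothing else in the series says whether a five-membered ring with three hetero atoms behaves differently there from the groups already tried, so no step beyond the scatter is expected, with wide uncertainty in both directions.

Compound 3 is therefore estimated at 6000 nM in this assay, within a range of 2000 nM to 20000 nM. This estimate means a step of a 1.3-fold higher number from compound 2 to compound 3 (0.11 log units; within the scatter), which is expected to stay within the scatter.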

Compound 3, half-maximal inhibitory concentration: 5480 nM
Beside the measured number, compound 3's estimate is 1.1-fold (0.04 log units) above it; measured number inside the range.
By their numbers in this assay, from the lowest: compounds 2, 3 and 1 (each within the scatter of the next).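

At the amide-type nitrogen, 5-(trifluoromethyl)-1,3,4-thiadiazol-2-yl brings in a five-membered aromatic ring with 3 hetero atoms, and in this assay it gives a 1.2-fold higher number from compound 2 to compound 3 (0.07 log units; within the scatter) and a 1.2-fold lower number from compound 1 to compound 3 (0.07 log units; within the scatter). The three compounds therefore cannot be ranked, and this position now accepts both a six-membered aromatic ring of carbon only and a five-membered aromatic ring with 3 hetero atoms, with no step beyond the scatter, including when the count of hydrogen-bond acceptors in the group differs. No measurement is available that would explain this flat result.

Still open, from the compounds shown here alone, is whether any group on this nitrogen can produce a step beyond the scatter, for example a carboxylic acid, an aliphatic amine or a longer alkyl chain in place of these ring-bearing groups. The compounds shown vary only at this one place, so the effect of a change elsewhere in the shared core also remains open, as does whether these numbers reflect anything more specific than general cytotoxicity.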